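Two Phenols at the Limit, and a Methyl Ether

The compounds below may be only part of what the source reports. "The series", "measured", "known", "first", "only" and "open" are said of these compounds alone.

Compound 1 `O=C1N[C@H]2[C@H](CS[C@H]2CCCCCc2cn(Cc3ccccc3O)nn2)N1` and compound 2 `O=C1N[C@H]2[C@H](CS[C@H]2CCCCCc2cn(Cc3cccc(O)c3)nn2)N1` share the same core and differ only in the hydroxyphenyl group on a saturated chain carbon bound to an aromatic nitrogen. In an assay on isolated protein for inhibition of biotin--protein ligase (Homo sapiens), read by scintillation counting, with a stated time of 10 min (a lower number here means a stronger inhibitor, a higher number a weaker inhibitor), compound 1 gives > 16000 nM, which is a limit of the assay rather than a measured number. Compound 2 in this assay gives > 16000 nM, likewise a limit. Because both values sit at the limit of > 16000 nM in this assay, at which 2 of the 2 values shown sit, the step that the two limits leave unreadable from compound 1 to compound 2 has no readable size. Compound 2 therefore stands at the edge of what the assay can report, and nothing shown separates it from compound 1.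

Compound 3 `COc1ccccc1Cn1cc(CCCCC[C@@H]2SC[C@@H]3NC(=O)N[C@@H]32)nn1` has not yet been measured. It differs from compound 2 by 2-methoxyphenyl in place of 3-hydroxyphenyl on a saturated chain carbon bound to an aromatic nitrogen. Among the compounds with values here, the single measured step, from compound 1 to compound 2, cannot be sized and so gives no direction for this change. Compound 3 is expected to give 20000 nM, with a range from 8000 nM to 60000 nM, most likely reported again as a limit. The expected step that the limit leaves unreadable from compound 2 to compound 3 is thus no more than the scatter allows.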

Compound 3, inhibition constant: > 16000 nM
Compound 3 gave a limit, no number; the forecaster's own chance of this, stated with the estimate: 80%; the middle value does not contradict the limit.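

Compound 3 gives > 16000 nM in this assay, again a limit and not a number. No new step can be read among compound 1, compound 2 and compound 3, because all three rest at the same limit: the limit of > 16000 nM in this assay, at which 3 of the 3 values shown sit.

Going by these compounds, whether the 3-hydroxyphenyl, 2-hydroxyphenyl and 2-methoxyphenyl groups differ at all in inhibition stays open.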